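The source may report more compounds than this note shows. Statements on the series, on what has been measured and on what is new or still open speak of the compounds shown alone.

Three compounds of the series carry numbers in an assay on L cells for inhibition of Protein-serine O-palmitoleoyltransferase porcupine (Mus musculus), read by reporter gene assay, with a stated time of 24 h (on this read-out higher numbers stand for an effect only at larger amounts of compound and lower numbers for an effect already at smaller amounts), so far. Compound 1 `O=C(CNC(=O)c1nn(-c2ccc(F)cc2)c(=O)c2ccccc12)Nc1nc2ccccc2s1` gives only a limit there, namely > 25000 nM in that read-out, which is the limit of > 25000 nM in this assay, at which 1 of the 3 values shown sits, for the series. Within the data shown here, compound 2 `O=C(CNC(=O)c1nn(-c2ccccc2)c(=O)c2ccccc12)Nc1nc2ccccc2s1` gives 2600 nM in this assay and the single measured one-place step is an at least 9.6-fold lower number from compound 1 to compound 2 (0.98 log units; beyond the scatter) on a different core. Compound 3 `O=C(CSc1nc2c(c(=O)n1-c1ccccc1)SCC2)Nc1ccc(N2CCCCC2)cc1` stands lowest of the two numbers with 30 nM in this assay and its nearest neighbour is compound 2. Compound 4 `CC(=O)c1ccc(NC(=O)CSc2nc3c(c(=O)n2-c2ccccc2)SCC3)cc1` differs from compound 3 by acetyl in place of piperidin-1-yl on an aromatic carbon only. Among the measured compounds shown here, no measured step touches this exchange, so the expectation rests on the change alone. The step from compound 3 to compound 4 is expected as a 6.7-fold higher number from compound 3 to compound 4 (0.82 log units; beyond the scatter) toward a higher number. Compound 4 is therefore estimated at 200 nM with a range from 30 nM to 1500 nM in this assay.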

Compound 4, half-maximal effective concentration: > 1000 nM
Compound 4 ended at the assay's limit; the forecaster's own chance of this, stated with the estimate: 5%; middle value at least 5.0-fold (0.69 log units) away from the limit.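

Acetyl in place of piperidin-1-yl, on an aromatic carbon para to a large group, gives an at least 33-fold higher number from compound 3 to compound 4 (1.52 log units; beyond the scatter) in this assay. Among these compounds, this is the first step read at this position, and it shows that the low number of compound 3 does not survive this exchange on the shared core. Compound 4 stands at a limit and not at a number: the limit of > 1000 nM in this assay, at which 1 of the 4 values shown sits.

The compounds shown leave open whether the ring of piperidin-1-yl or its nitrogen matters here. A morpholine or an open-chain dimethylamino group at this place would separate the two.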